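Amide replacements on the ring nitrogen of the shared core

A few compounds are considered here, and "the series" means these few. Any claim that something is new, unique, unknown or untested is made for them only; others in the source may bear on it.

Working notes on a small series sharing one core. Compound 1 `CCCCNc1nc(N)nc2c1CN(Cc1ccccc1Cl)CC2` gives 0.05 uM in an assay on HEK293 cells for agonist activity at Toll-like receptor 8 (Homo sapiens), read by a luciferase reporter, with a stated time of 6 h (on this read-out lower numbers stand for an effect already at smaller amounts and higher numbers for an effect only at larger amounts of compound), and compound 2 `CCCCNc1nc(N)nc2c1CN(Cc1ccco1)CC2` gives 0.08 uM; the two values lie within the scatter of each other, so no order between them is claimed. Compound 3 `CCCCNc1nc(N)nc2c1CN(C(=O)C1CCC1)CC2`, which carries a cyclobutylcarbonyl on the amine nitrogen in the ring, gives 0.4 uM and stands highest of the three numbers; the steps of an 8.0-fold higher number from compound 1 to compound 3 (0.90 log units; beyond the scatter) and a 5.0-fold higher number from compound 2 to compound 3 (0.70 log units; beyond the scatter) are both beyond the scatter and modest in size.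

Compound 4 `CCCCNc1nc(N)nc2c1CN(C(=O)c1csc(C)n1)CC2` has not yet been measured. It differs from compound 3 in one place: 2-methyl-1,3-thiazol-4-yl in place of cyclobutyl on a carbonyl carbon. The carbonyl on the amine nitrogen in the ring is kept; only the group on that carbonyl carbon changes.

Both measured steps that bear on this position replace a whole group on the ring nitrogen rather than a group on the carbonyl carbon, so they speak to the change only indirectly. They show that compound 3 sits at the weaker end of the series, which leaves room for a step in either direction. A step of about a 1.3-fold lower number from compound 3 to compound 4 (0.12 log units; within the scatter) is expected, with wide uncertainty. Compound 4 is therefore estimated at 0.3 uM, with a range from 0.08 uM to 1.5 uM.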

Compound 4, minimum effective concentration: 1.8 uM
For compound 4 the middle estimate is 6.0-fold (0.78 log units) below the measured one, and the stated range ends below it.
By their numbers in this assay, from the lowest: compounds 1 and 2 (each within the scatter of the next); then compound 3; then compound 4.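

In this assay, for the compounds shown here, the group on the carbonyl carbon proves to matter in its own right: with the carbonyl on the amide-type nitrogen in the ring kept, 2-methyl-1,3-thiazol-4-yl in place of cyclobutyl gives a 4.5-fold higher number from compound 3 to compound 4 (0.65 log units; beyond the scatter) as a step beyond the scatter, which the earlier steps, each replacing a whole group on the ring nitrogen, could not isolate. The steps of a 23-fold higher number from compound 2 to compound 4 (1.35 log units; beyond the scatter) and a 36-fold higher number from compound 1 to compound 4 (1.56 log units; beyond the scatter) are both large, so among these four compounds the two carrying a carbonyl on the ring nitrogen stand above the two carrying a (furan-2-yl)methyl or 2-chlorobenzyl group, with no compound here going against that, and compound 4 stands highest. Nothing at hand accounts for the step from cyclobutyl to the thiazolyl group.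

As far as these compounds go, it remains open whether the higher number belongs to the five-membered aromatic ring itself or to the methyl group on it, which a comparison with the unsubstituted 1,3-thiazol-4-yl group would separate. Also open, from the compounds shown here alone, is where a phenyl group, a dimethylamino group or a longer alkyl chain on the carbonyl carbon would fall relative to compound 3 and compound 4.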